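This account rests on a few compounds, and the source may have more. Where it says the series, first, only, none or still open, it means among the compounds named here.

Measured compounds:
- compound 1 `O=[N+]([O-])c1cc(OCc2ccccc2)ccc1CNc1cc(C(F)(F)F)cc2[nH]ncc12` — 10%
- compound 2 `NCCn1ncc2c(NCc3ccccc3[N+](=O)[O-])cc(C(F)(F)F)cc21` — 9%

In an assay for inhibition of Indoleamine 2,3-dioxygenase 1 (Homo sapiens), with stated times of 10 min and 60 min, tested at 10 uM (a higher number here means a stronger effect of the compound at the concentration tested, a lower number a weaker effect), compound 1 gives 10%, and compound 2 gives 9%. The two numbers lie within the usual scatter of each other, so neither compound can be set apart from the other; both show only a small effect at the concentration tested. Compound 1 thus stands at a low level, with compound 2 beside it.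

Compound 3 `O=[N+]([O-])c1cc(Cl)ccc1CNc1cc(C(F)(F)F)cc2[nH]ncc12` has not yet been measured in this assay. It differs from compound 1 in one place: chloro in place of benzyloxy on an aromatic carbon. Going by the values given here, no step between two measured compounds exists to show what such a change does here. Given the low numbers of both measured compounds, compound 3 is expected to stay near compound 1, with a step of a number 1 percentage points lower from compound 1 to compound 3 (within the scatter) that does not go beyond the scatter in either direction. The estimate for compound 3 in this assay is 9%, with a range from -5% to 25%.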

Compound 3, a percentage reported as inhibition, at one concentration (the size of the read-out at that concentration, not a potency): 50%
Beside the measured number, compound 3's estimate is 41 percentage points below it, outside the stated range (above it).
By their numbers in this assay, from the lowest: compounds 2 and 1 (each within the scatter of the next); then compound 3.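

In this assay, the position para to a large group and meta to a nitro group proves able to move the read-out: chloro in place of benzyloxy gives a number 40 percentage points higher from compound 1 to compound 3 (beyond the scatter). Compound 1 and compound 2 lay within the scatter of each other and differ in more than one place, so they gave no sign of this; here a single change lifts the compound clear of that low level, with the benzyloxy group and its six-membered aromatic ring gone. The data at hand offer no explanation for the size of this step.

Still open, going by these compounds, is whether the loss of benzyloxy or the arrival of chloro carries the gain, a question that a methoxy group, a fluoro group or a plain hydrogen at this position could help to settle. Also open, on these data alone, is whether the gain survives when chloro is combined with the aminoethyl chain of compound 2.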